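The source may report more compounds than this note shows. Statements on the series, on what has been measured and on what is new or still open speak of the compounds shown alone.

Working notes on the coumarin-enaminone sulfonamide series. Compound 3 `Cc1ccnc(NS(=O)(=O)c2ccc(N/C=C\C(=O)c3cc4ccccc4oc3=O)cc2)n1` stands lowest of the three numbers in a functional assay on T47D cells (Homo sapiens) for cytotoxicity, read by sulforhodamine B assay, with a stated time of 48 h (a lower number here means a stronger inhibitor, a higher number a weaker inhibitor), with 24500 nM. Compound 1 `Cc1cc(NS(=O)(=O)c2ccc(N/C=C\C(=O)c3cc4ccccc4oc3=O)cc2)on1` gives 75600 nM and compound 2 `Cc1nnc(NS(=O)(=O)c2ccc(N/C=C\C(=O)c3cc4ccccc4oc3=O)cc2)s1` gives 94000 nM; the steps are a 1.2-fold higher number from compound 1 to compound 2 (0.09 log units; within the scatter), a 3.1-fold lower number from compound 1 to compound 3 (0.49 log units; beyond the scatter) and a 3.8-fold lower number from compound 2 to compound 3 (0.58 log units; beyond the scatter). Compound 4 `O=C(/C=C\Nc1ccc(S(=O)(=O)Nc2ccc3cn[nH]c3c2)cc1)c1cc2ccccc2oc1=O` carries the change (1H-indazol-6-yl in place of 4-methylpyrimidin-2-yl on a sulfonamide nitrogen). Among the measured compounds shown here, no measured step exchanges a monocyclic heteroaryl for a bicyclic one, so only the modest shifts among the three heteroaryl sulfonamides bear on it, and the direction is open. A step around a 1.4-fold higher number from compound 3 to compound 4 (0.15 log units; within the scatter) in this assay is expected, with wide uncertainty. Compound 4 is estimated at 35000 nM, within 8000 nM to 150000 nM.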

Compound 4, half-maximal inhibitory concentration: 96500 nM
Estimate against measurement, compound 4: 2.8-fold (0.44 log units) below; the range from low to high includes it.
By their numbers in this assay, from the lowest: compound 3; then compounds 1, 2 and 4 (each within the scatter of the next).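

In this assay, 1H-indazol-6-yl on a sulfonamide nitrogen loses what 4-methylpyrimidin-2-yl gained (a 3.9-fold higher number from compound 3 to compound 4 (0.60 log units; beyond the scatter)) and is level with the two smaller groups (a 1.0-fold higher number from compound 2 to compound 4 (0.01 log units; within the scatter); a 1.3-fold higher number from compound 1 to compound 4 (0.11 log units; within the scatter)). Compound 3 therefore remains the only one of the four set apart, and the larger group with its hydrogen-bond donor brings no gain. No evidence at hand bears on the reason for this result.

As far as these compounds go, it remains open whether an amine or a methoxy group in place of the methyl of 4-methylpyrimidin-2-yl would keep the lower number. From the compounds shown here alone, a plain phenyl on the same nitrogen, which would show whether the ring nitrogens matter, is also open.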